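Removing a boron-bearing group from compound 2

A few compounds are considered here, and "the series" means these few. Any claim that something is new, unique, unknown or untested is made for them only; others in the source may bear on it.

Of the compounds shown here, two have been measured so far. In a functional assay on MV4-11 cells (Homo sapiens) for cytotoxicity, read by MTT assay, with a stated time of 72 h (on this read-out lower numbers stand for stronger inhibition and higher numbers for weaker inhibition), compound 1 `O=C(CCCCCCC(=O)Nc1ccccc1)NOCc1ccc(B(O)O)cc1` gives 3070 nM, while compound 2 `COc1cc(/C=C/C(=O)N2CCC=CC2=O)cc(OC)c1OCCCCCCC(=O)NOCc1ccc(B(O)O)cc1` gives 700 nM, the lower of the two numbers and a gap beyond the usual scatter. Compound 3 `COc1cc(/C=C/C(=O)N2CCC=CC2=O)cc(OC)c1OCCCCCCC(=O)NO` has not yet been measured. It differs from compound 2 in one place: a hydrogen atom in place of a group of 10 heavy atoms (7 carbon, 1 boron, 2 oxygen; one six-membered aromatic ring of carbon only), on an oxygen, so a hydrogen atom stands in place of that group, on an oxygen. Among the measured compounds shown here, compound 1 carries the same group, so no measured pair shows what its loss does, and the expectation rests on the structural change alone. A moderate move towards stronger inhibition in this assay is expected, with wide uncertainty. The expected change is a 2.8-fold lower number from compound 2 to compound 3 (0.45 log units; beyond the scatter). For compound 3, the estimated value is 250 nM, with a range from 70 nM to 800 nM.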

Compound 3, half-maximal inhibitory concentration: 230 nM
Compound 3: the middle estimate sits 1.1-fold (0.04 log units) above what was measured, within the range that was stated.
By their numbers in this assay, from the lowest: compound 3; then compound 2; then compound 1.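

In this assay, replacing the group of 10 heavy atoms with a hydrogen atom, on an oxygen whose other neighbour is an amide-type nitrogen, gives a 3.0-fold lower number from compound 2 to compound 3 (0.48 log units; beyond the scatter), a modest step beyond the scatter. Among the compounds shown here, this is the first direct reading of this change, and it shows that the boron-bearing group is not needed on this oxygen for activity here, as the form with only a hydrogen gives the lower number. For the compounds shown here, nothing measured so far bears on the reason for this step.

With only these two groups shown on this oxygen, a benzyl group without the boron would be needed to separate the part played by the boron from that of the ring. Going by these compounds, whether the same exchange would lower the number of compound 1 also stays open.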